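The source may report more compounds than this note shows. Statements on the series, on what has been measured and on what is new or still open speak of the compounds shown alone.

Of the compounds shown here, three built on one shared core have been measured in a functional assay on SU-DHL-6 cells (Homo sapiens) for antiproliferative activity, read by MTT assay; on this read-out higher numbers stand for weaker inhibition and lower numbers for stronger inhibition. There, compound 1 `COc1ncc(-c2ccc3ncnc(N[C@H]4CCCN(C(=O)CCBr)C4)c3c2)cc1C#N` gives 15 nM, compound 2 `COc1ncc(-c2ccc3ncnc(N[C@H]4CCCN(C(=O)CCl)C4)c3c2)cc1C#N` gives 380 nM and compound 3 `CCOC(=O)CN1CCC[C@H](Nc2ncnc3ccc(-c4cnc(OC)c(C#N)c4)cc23)C1` gives 500 nM. Compound 3 therefore stands level with compound 2, the gap being a 1.3-fold higher number from compound 2 to compound 3 (0.12 log units; within the scatter), and far from compound 1, the gap being a 33-fold higher number from compound 1 to compound 3 (1.52 log units; beyond the scatter).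

Compound 4 `COc1ncc(-c2ccc3ncnc(N[C@H]4CCCN(C(=O)C5CCNCC5)C4)c3c2)cc1C#N` has not yet been measured. It differs from compound 3 as follows: (piperidin-4-yl)carbonyl in place of (ethoxycarbonyl)methyl on an amine nitrogen in a ring. In short, (piperidin-4-yl)carbonyl replaces (ethoxycarbonyl)methyl on the amine nitrogen in the ring.

The closest guide is a 1.3-fold higher number from compound 2 to compound 3 (0.12 log units; within the scatter), a swap at the same nitrogen that produced no real change. The large steps, a 25-fold higher number from compound 1 to compound 2 (1.40 log units; beyond the scatter) and a 33-fold higher number from compound 1 to compound 3 (1.52 log units; beyond the scatter), both involve the (2-bromoethyl)carbonyl group of compound 1, which compound 4 lacks. Among the compounds with values here, no step beyond the scatter is therefore expected in this assay, although no measured compound carries this ring at that nitrogen, so the range stays wide. The expected change is a 1.3-fold lower number from compound 3 to compound 4 (0.10 log units; within the scatter). The estimated value for compound 4 is 400 nM, within an expected range of 100 nM to 1600 nM.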

Compound 4, half-maximal inhibitory concentration: 2440 nM
The estimate for compound 4 lay 6.1-fold (0.79 log units) below the measured number, and the stated range ends below it.
By their numbers in this assay, from the lowest: compound 1; then compounds 2 and 3 (each within the scatter of the next); then compound 4.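

In this assay the amine nitrogen in the ring proves sensitive even without the (2-bromoethyl)carbonyl group: there is a 4.9-fold higher number from compound 3 to compound 4 (0.69 log units; beyond the scatter) and also a 6.4-fold higher number from compound 2 to compound 4 (0.81 log units; beyond the scatter) as steps beyond the scatter, although compound 2 and compound 3 stand level. With piperidin-4-yl on the carbonyl carbon, the widest gap in the set appears as a 160-fold higher number from compound 1 to compound 4 (2.21 log units; beyond the scatter) and so sets the bromo-bearing chain further apart from every other group shown here. No measured evidence accounts for the rise in number at this position.

Still open, from the compounds shown here alone, is whether the ring itself or its nitrogen-bound hydrogen goes with the weaker inhibition, a question that a cyclohexyl or 1-methylpiperidin-4-yl group on the same carbonyl could help settle. Going by these compounds, whether a small acetyl group at this nitrogen would sit closer to compound 3 or to compound 4 also remains unknown.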